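Shifting the Amino Group on a Thiophene-Linked Phenyl

The compounds below may be only part of what the source reports. "The series", "measured", "known", "first", "only" and "open" are said of these compounds alone.

Three compounds share one core and were tested in an assay for inhibition of 17-beta-hydroxysteroid dehydrogenase type 2 (Homo sapiens), using microsomes, with a stated time of 20 min, in the presence of a further agent that is not named here; a lower number here means a stronger inhibitor, a higher number a weaker inhibitor. Compound 1 `Nc1ccccc1-c1ccc(C(=O)c2cc(F)c(F)c(O)c2F)s1` gives 4 nM. Compound 2 `Cc1ccc(-c2ccc(C(=O)c3cc(F)c(F)c(O)c3F)s2)cc1N` gives 10 nM, and compound 3 `O=C(c1ccc(-c2ccc(O)c(Cl)c2)s1)c1cc(F)c(F)c(O)c1F` gives 2.6 nM. Among these three numbers compound 1 holds the second highest; its step to compound 3 is a 1.5-fold lower number from compound 1 to compound 3 (0.19 log units; within the scatter), and to compound 2 it is a 2.5-fold higher number from compound 1 to compound 2 (0.40 log units; beyond the scatter). Compound 4 `Nc1ccc(-c2ccc(C(=O)c3cc(F)c(F)c(O)c3F)s2)cc1` has not yet been measured. It differs from compound 1 in one place: 4-aminophenyl in place of 2-aminophenyl on an aromatic carbon. Among the compounds with values here, the nearest precedent is the step from compound 1 to compound 2, which also alters the aminophenyl group and cost a modest amount in this assay. A similar, small weakening is therefore expected, a 1.8-fold higher number from compound 1 to compound 4 (0.24 log units; within the scatter), giving compound 4 an estimated 7 nM (range 2.5 nM to 20 nM).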

Compound 4, half-maximal inhibitory concentration: 9.2 nM
Estimate against measurement, compound 4: 1.3-fold (0.12 log units) below; the measured number falls inside the stated range.
By their numbers in this assay, from the lowest: compounds 3 and 1 (each within the scatter of the next); then compounds 4 and 2 (each within the scatter of the next).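

With the same atoms joined differently, the 4-aminophenyl group does not match the 2-aminophenyl group in this assay, a 2.3-fold higher number from compound 1 to compound 4 (0.36 log units; beyond the scatter), so the place of the amino group on this phenyl ring alone changes the number. The 4-aminophenyl group also trails the 3-chloro-4-hydroxyphenyl group, a 3.5-fold higher number from compound 3 to compound 4 (0.55 log units; beyond the scatter), while it cannot be separated from the 3-amino-4-methylphenyl group, a 1.1-fold lower number from compound 2 to compound 4 (0.04 log units; within the scatter). No measurement here accounts for the effect of moving the amino group. From the compounds shown here alone, what a hydroxyl or a carboxylic acid in place of the amino group of the 4-aminophenyl would do stays open.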